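From 2-methoxyphenyl to 2-phenylethenyl on the shared core

A few compounds are considered here, and "the series" means these few. Any claim that something is new, unique, unknown or untested is made for them only; others in the source may bear on it.

In a functional assay on MCF7 cells (Homo sapiens) for cytotoxicity, read by MTT assay, with a stated time of 96 h (a higher number here means a weaker inhibitor, a lower number a stronger inhibitor), compound 1 (`COc1cc(C(=O)c2cn(-c3ccccc3)cc2-c2ccc(Cl)cc2)cc(OC)c1OC`) gives 290 nM and compound 2 (`COc1ccccc1-c1cn(-c2ccccc2)cc1C(=O)c1cc(OC)c(OC)c(OC)c1`) gives 190 nM which puts compound 2 level with compound 1 within the scatter. Compound 3 (`COc1cc(C(=O)c2cn(-c3ccccc3)cc2/C=C/c2ccccc2)cc(OC)c1OC`) carries 2-phenylethenyl in place of 2-methoxyphenyl on an aromatic carbon. For the measured compounds named here, the one measured step at that carbon is a 1.5-fold lower number from compound 1 to compound 2 (0.18 log units; within the scatter) and it stayed within the scatter, so no shift beyond the scatter is expected in this assay although that step says nothing about a double bond. The expected step is a 1.5-fold higher number from compound 2 to compound 3 (0.17 log units; within the scatter) as an estimate only. For compound 3 the estimated value is 280 nM with an expected range of 80 nM to 1000 nM in this measurement.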

Compound 3, half-maximal inhibitory concentration: 2200 nM
For compound 3 the middle estimate is 7.9-fold (0.90 log units) below the measured one; measured number above the stated range.
By their numbers in this assay, from the lowest: compounds 2 and 1 (each within the scatter of the next); then compound 3.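

In this assay, this carbon proves sensitive to the group it carries, which the earlier step between two substituted phenyl groups did not reveal: the change to 2-phenylethenyl gives a 12-fold higher number from compound 2 to compound 3 (1.06 log units; beyond the scatter) and a 7.6-fold higher number from compound 1 to compound 3 (0.88 log units; beyond the scatter). The entering and leaving groups in the first of these steps have the same count of heavy atoms, so that count does not separate them. Nothing measured here explains the loss. Going by these compounds, whether it follows from the double bond itself remains open. On these data alone, how a saturated 2-phenylethyl group or an amine would behave at this carbon also remains open.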